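Butyl in place of bromo: compound 1 to compound 4

A few compounds are considered here, and "the series" means these few. Any claim that something is new, unique, unknown or untested is made for them only; others in the source may bear on it.

Compound 1 `O=C(CSC(=S)N[C@H]1CCOC1=O)Nc1ccc(Br)cc1` gives 67400 nM in a functional assay on EC9706 cells (Homo sapiens) for cytotoxicity, read by MTT assay, with a stated time of 72 h; a lower number here means a stronger inhibitor, a higher number a weaker inhibitor. Compound 3 `O=C(CSC(=S)N[C@H]1CCOC1=O)Nc1cccc(C(F)(F)F)c1` gives 79700 nM in this assay; the two numbers sit within the scatter of each other. Compound 2 `Cc1cccc(NC(=O)CSC(=S)N[C@H]2CCOC2=O)c1` reached only the limit > 128000 nM in this assay. Among the numbers shown, compound 1 holds the lowest, with compound 3 nearest.

The step from compound 1 to compound 4 `CCCCc1ccc(NC(=O)CSC(=S)N[C@H]2CCOC2=O)cc1` is butyl in place of bromo on an aromatic carbon. Among the measured compounds shown here, no measured step makes this same change. The nearest comparisons are an at least 1.8-fold higher number from compound 1 to compound 2 (0.27 log units; that floor lies within the scatter) and an at least 1.6-fold lower number from compound 2 to compound 3 (0.20 log units; that floor lies within the scatter); both carry floors that lie within the scatter. The first of these ends at a limit of compound 2: the limit of > 128000 nM in this assay, at which 1 of the 3 values shown sits. Neither step involves a butyl, and neither settles the direction of a change on that aromatic carbon. The expectation for compound 4 is therefore a step of about a 1.2-fold higher number from compound 1 to compound 4 (0.07 log units; within the scatter), not clearly beyond the scatter. Compound 4 is estimated at 80000 nM, with a range from 35000 nM to 180000 nM.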

Compound 4, half-maximal inhibitory concentration: 44200 nM
Compound 4: middle estimate off by 1.8-fold (0.26 log units), on the high side, and the stated range covers the measured number.
By their numbers in this assay, from the lowest: compounds 4, 1 and 3 (each within the scatter of the next). At a limit, above all of these: compound 2.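

Butyl in place of bromo on this aromatic carbon gives a 1.5-fold lower number from compound 1 to compound 4 (0.18 log units; within the scatter) in this assay, the first step in the series that acts directly on this position. Among the compounds shown here, at this position, bromo and butyl therefore cannot be told apart in this assay, even though the groups differ in size by the heavy-atom count, whereas the earlier steps each had compound 2's limit at one end and gave only floors. No measured property shown here accounts for this step.

From the compounds shown here alone, whether an amine, a carboxylic acid or a longer chain such as octyl on this aromatic carbon would give a number beyond the scatter of compound 1 remains open. Also open, going by these compounds, is how far the shared core can go below these values, since all numerical values shown stay within the scatter of their neighbours.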